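Methyl in Place of Fluoro: Compound 4 Expected

The source may report more compounds than this note shows. Statements on the series, on what has been measured and on what is new or still open speak of the compounds shown alone.

Compound 1 `CNC(=O)c1ccc(Oc2cccc(NC(=S)Nc3ccc(F)cc3)c2)nc1` — 42500 nM
Compound 2 `CNC(=O)c1ccc(Oc2cccc(NC(=S)Nc3ccc(OC(F)(F)F)cc3)c2)nc1` — > 100000 nM (a limit)
Compound 3 `CNC(=O)c1ccc(Oc2cccc(NC(=S)Nc3ccc(C)c(C)c3)c2)nc1` — > 100000 nM (a limit)

Among the measured compounds shown here, in a functional assay on HepG2 cells (Homo sapiens) for antiproliferative activity, read by MTT assay (a lower number here means a stronger inhibitor, a higher number a weaker inhibitor), compound 1 gives 42500 nM, the only plain number among the three measured compounds. Compound 2 gives only a limit of this assay, > 100000 nM. Compound 3 likewise gives only a limit, > 100000 nM. Both measured steps therefore lead away from compound 1: an at least 2.3-fold higher number from compound 1 to compound 2 (0.37 log units; beyond the scatter) and an at least 2.3-fold higher number from compound 1 to compound 3 (0.37 log units; beyond the scatter). Both end at the limit of > 100000 nM in this assay, at which 2 of the 3 values shown sit, so the true size of either step is not known beyond its lower bound.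

Compound 4 `CNC(=O)c1ccc(Oc2cccc(NC(=S)Nc3ccc(C)cc3)c2)nc1` has not yet been measured. It differs from compound 1 in one place: methyl in place of fluoro on an aromatic carbon. The two measured steps bear on it, since each also alters the group on that aromatic carbon of the ring bound to the amide-type nitrogen; the step to compound 3 adds a methyl among other things. Both were at least modest and both went toward a weaker number. Compound 4 is therefore expected to give a higher number, a 2.4-fold higher number from compound 1 to compound 4 (0.37 log units; beyond the scatter), with a fair chance that only a limit is reported. The estimate for compound 4 is 100000 nM, between 40000 nM and 250000 nM.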

Compound 4, half-maximal inhibitory concentration: 65400 nM
For compound 4 the middle estimate is 1.5-fold (0.18 log units) above the measured one; low and high end bracket the measured number.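

Among the compounds shown here, on this aromatic carbon, para to a large group, methyl in place of fluoro gives a 1.5-fold higher number from compound 1 to compound 4 (0.19 log units; within the scatter) in this assay, so compound 1 and compound 4 cannot be told apart, and replacing fluoro here need not produce a step beyond the scatter, as the earlier steps to compound 2 and compound 3 alone might have suggested. Those two compounds still stand apart from compound 1, so the pattern depends on the group that enters. Against compound 4 they give only floors, an at least 1.5-fold lower number from compound 3 to compound 4 (0.18 log units; that floor lies within the scatter) and an at least 1.5-fold lower number from compound 2 to compound 4 (0.18 log units; that floor lies within the scatter), and neither floor separates them from compound 4: the limit of > 100000 nM in this assay, at which 2 of the 4 values shown sit.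

On these data alone, whether an amine or a carboxylic acid on this aromatic carbon would read clearly apart from fluoro and methyl stays open. So does whether chloro or methoxy would match them.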